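Dichloropurine benzyl series: from compound 3 to compound 4

The source may report more compounds than this note shows. Statements on the series, on what has been measured and on what is new or still open speak of the compounds shown alone.

Compound 3 `ClCc1ccc(Cn2cnc3ncnc(Cl)c32)cc1` has no number in a functional assay on HCT-15 cells (Homo sapiens) for cytotoxicity, read by sulforhodamine B assay, with a stated time of 48 h; on this read-out higher numbers stand for lower toxicity in this test and lower numbers for higher toxicity in this test; for compound 3 the entry reads "not determined" (no result reported), so it stands nowhere on the scale and is known only through its neighbours. Two related compounds carry numbers. Compound 2 `ClCc1cccc(Cn2cnc3nc(Cl)nc(Cl)c32)c1` gives 4570 nM in this assay. Compound 1 `Nc1nc(Cl)c2ncn(Cc3ccc(CCl)cc3)c2n1` gives 67600 nM in this assay. Going by the values given here, these two differ in more than one place, so what they show is only that the two measured members sit far apart on the read-out.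

Compound 4 `ClCc1ccc(Cn2cnc3nc(Cl)nc(Cl)c32)cc1` is the next member. The change from compound 3 to compound 4 is chloro in place of hydrogen on an aromatic carbon. Among the compounds with values here, no measured step is available for this change; the direction and size in this assay cannot be read from a measured pair. Compound 4 carries the same two chloro groups on its core as compound 2, whose value of 4570 nM is the closest anchor available. Compound 1 carries a different group on the core and sits much higher.

On that basis compound 4 is expected to come in near compound 2, estimated at 7000 nM, with a range from 2000 nM to 30000 nM in this assay.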

Compound 4, concentration lethal to 50% of the cells: 6760 nM
Compound 4: middle estimate off by 1.0-fold (0.02 log units), on the high side; measured number inside the range.
By their numbers in this assay, from the lowest: compounds 2 and 4 (each within the scatter of the next); then compound 1.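

No step can be read from compound 3 to compound 4: in this assay compound 4 gives 6760 nM against no number for compound 3. The compounds shown leave open what chloro in place of hydrogen on the shared core does on this read-out. No evidence bears on this result.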